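Swapping the halogenated ring on the hydrazone carbon

A few compounds are considered here, and "the series" means these few. Any claim that something is new, unique, unknown or untested is made for them only; others in the source may bear on it.

Of the compounds shown here, two sharing one core have been measured in an ADME assay on THP-1 cells (Homo sapiens) for cytotoxicity; a higher number here means a weaker inhibitor, a lower number a stronger inhibitor. Compound 1 `COc1ccccc1-c1nnc(-c2ccc(C(=O)N/N=C/c3ccncc3)cc2)o1` gives 173000 nM. Within the data shown here, compound 2 `COc1ccccc1-c1nnc(-c2ccc(C(=O)N/N=C/c3ccccc3F)cc2)o1` gives 313000 nM in this assay; this is the higher of the two numbers, and compound 1, the only neighbour, sits within the scatter of it.

Compound 3 `COc1ccccc1-c1nnc(-c2ccc(C(=O)N/N=C/c3ccc(Cl)cc3Cl)cc2)o1` differs from compound 2 by 2,4-dichlorophenyl in place of 2-fluorophenyl on a carbon with a double bond to nitrogen. Among the measured compounds shown here, only one measured step bears on this position: the change a 1.8-fold higher number from compound 1 to compound 2 (0.26 log units; within the scatter), which also exchanged the ring on the carbon with a double bond to nitrogen and stayed within the scatter. With one aromatic ring again replacing another at the same place, no movement beyond the scatter is expected in this assay, in either direction, and the step expected is a 1.0-fold lower number from compound 2 to compound 3 (0.02 log units; within the scatter). Compound 3 is therefore estimated at 300000 nM, with a range from 120000 nM to 750000 nM.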

Compound 3, half-maximal inhibitory concentration: 78800 nM
Compound 3: the middle estimate sits 3.8-fold (0.58 log units) above what was measured; the measured number lies below the stated range.
By their numbers in this assay, from the lowest: compound 3; then compounds 1 and 2 (each within the scatter of the next).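

The carbon with a double bond to nitrogen turns out to be a place where the ring can change the result in this assay: 2,4-dichlorophenyl gives a 4.0-fold lower number from compound 2 to compound 3 (0.60 log units; beyond the scatter) and a 2.2-fold lower number from compound 1 to compound 3 (0.34 log units; beyond the scatter) when it replaces pyridin-4-yl. The earlier exchange of pyridin-4-yl for 2-fluorophenyl stayed within the scatter, so not every ring swap here matters, and compound 3 now has the lowest number of the three, beyond the scatter from both others. Nothing available explains why this ring lowers the number.

Still open, from the compounds shown here alone, is whether one chlorine would do as much as two, which 4-chlorophenyl or 2-chlorophenyl on this carbon would test. It is also unknown how rings carrying a different group, such as a methoxy group or an amine, would behave here.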